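Benzylamide series: acid in place of acetamido

The compounds below may be only part of what the source reports. "The series", "measured", "known", "first", "only" and "open" are said of these compounds alone.

The series shares the core shown in compound 1 `CN(C)C(=O)c1ccc(CNC(=O)c2ccc(C(C)(C)C)cc2)cc1`, which carries a dimethylcarbamoyl group, and compound 2 `CC(=O)Nc1ccc(CNC(=O)c2ccc(C(C)(C)C)cc2)cc1`, which carries acetamido in its place. In an assay on HeLa cells with Bile acid receptor (Homo sapiens) as the target, read by a luciferase reporter, with a stated time of 24 h (a higher number here means that more compound is needed for the effect, a lower number that less compound is needed), compound 1 gives 170 nM. In this assay, among the measured compounds shown here, compound 2 gives 2900 nM, the higher of the two numbers so far, set apart from compound 1 by a 17-fold higher number from compound 1 to compound 2 (1.23 log units; beyond the scatter), the only measured step in the set. Compound 3 `CC(C)(C)c1ccc(C(=O)NCc2ccc(OCC(=O)O)cc2)cc1` is not yet measured; it differs from compound 2 by carboxymethoxy in place of acetamido on an aromatic carbon. For the measured compounds named here, no measured step exchanges acetamido for carboxymethoxy. Going by the values given here, the one known step shows only that a change at this position can move this assay well beyond the scatter; it does not fix the direction for compound 3, and the two groups are unlike in what is counted. For compound 3 the expected step is a 1.2-fold lower number from compound 2 to compound 3 (0.06 log units; within the scatter), within the scatter, held near compound 2 for want of a closer comparison. In this assay compound 3 is therefore expected to give about 2500 nM, with a range from 400 nM to 15000 nM.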

Compound 3, half-maximal effective concentration: 730 nM
Compound 3: the middle estimate sits 3.4-fold (0.53 log units) above what was measured, within the range that was stated.
By their numbers in this assay, from the lowest: compound 1; then compound 3; then compound 2.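

Working notes on the position para to a large group, read in this assay: carboxymethoxy in place of acetamido gives a 4.0-fold lower number from compound 2 to compound 3 (0.60 log units; beyond the scatter) and carboxymethoxy in place of dimethylcarbamoyl gives a 4.3-fold higher number from compound 1 to compound 3 (0.63 log units; beyond the scatter) so compound 3 falls between the two earlier compounds, and the position now shows a graded order of three groups rather than a single large gap. Acetamido and carboxymethoxy match in several counted features, with no ring, a single double bond outside aromatic rings, a single hydrogen-bond donor and no net charge, yet the step between them lies beyond the scatter, so these shared counts do not hold the number in place across the series. The data shown offer no measurement that accounts for the order of these three groups.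

On these data alone, it remains open whether the ether oxygen or the terminal acid of carboxymethoxy matters more, a question that a carboxylic acid joined directly to the ring, a methyl ester or a longer chain ending in the acid could address. Whether any group at this place gives a lower number than dimethylcarbamoyl in compound 1 is also unsettled, with a diethylcarbamoyl group or a simple amine as possible probes.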